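The compounds below may be only part of what the source reports. "The series", "measured", "known", "first", "only" and "open" are said of these compounds alone.

In an ADME assay (liver) for metabolic stability, with Liver microsome (Rattus norvegicus) as the target, read by LC-MS, using microsomes, with a stated time of 30 min, tested at 4 uM (a higher number here means that more of the compound is left, a lower number that less of the compound is left), compound 1 (`Cc1nc(N2CCN(C)CC2)c2nc(-c3ccccc3C)n(C3CCOCC3)c2n1`) retains 39% while compound 2 (`CCc1ccccc1-c1nc2c(N3CCN(C)CC3)nc(C)nc2n1C1CCOCC1`), with 51% left, stands higher of the two. Compound 3 (`COc1ccc(-c2nc3c(N4CCN(C)CC4)nc(C)nc3n2C2CCOCC2)c(C)c1`) carries 4-methoxy-2-methylphenyl in place of 2-ethylphenyl on an aromatic carbon. Within the data shown here, the one measured step that bears on this is a number 12 percentage points higher from compound 1 to compound 2 (beyond the scatter) for a methyl in place of hydrogen on a chain carbon. Here the ethyl gives way to a methyl, and no measured compound carries a methoxy. A drop of similar size in this assay is therefore expected, an estimated a number 13 percentage points lower from compound 2 to compound 3 (beyond the scatter) overall. The estimate for compound 3 is 38% with 20% to 55% as its range.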

Compound 3, percent of the compound remaining: 24%
For compound 3 the middle estimate is 14 percentage points above the measured one; measured number inside the range.
By their numbers in this assay, from the lowest: compound 3; then compound 1; then compound 2.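

In this assay, methoxy in place of hydrogen on the phenyl ring gives a number 15 percentage points lower from compound 1 to compound 3 (beyond the scatter) on its own, so the number at this position responds to a change on the ring as well as to one in the chain. Going from 2-ethylphenyl to 4-methoxy-2-methylphenyl gives a number 27 percentage points lower from compound 2 to compound 3 (beyond the scatter) when the two changes come together. No measurement at hand explains why the number falls. Going by these compounds, whether this drop belongs to methoxy in particular stays open, as would be tested by a fluorine or a hydroxyl on the same ring carbon.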